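A few compounds are considered here, and "the series" means these few. Any claim that something is new, unique, unknown or untested is made for them only; others in the source may bear on it.

Series notes. Within the data shown here, compound 2, `COc1ccc(C(=O)O)cc1OCCCCOc1ccc(C(=O)CC2CCCC2)c(O)c1C`, carries the only number so far in an assay on HEK293 cells for positive allosteric modulation of metabotropic glutamate receptor 3 (Rattus norvegicus), read by thallium flux, with a stated time of 2.5 min; a higher number here means that more compound is needed for the effect, a lower number that less compound is needed: in this assay compound 2 gives 1020 nM. Compound 1, `Cc1c(OCCCCOc2ccccc2C(=O)O)ccc(C(=O)CC2CCCC2)c1O`, has no result in this assay, the entry reading "not determined" (no result reported). Among the measured compounds shown here, with a single number and nothing beside it, no step between measured compounds can be drawn, and no direction is known for any change. The next compound, compound 3, is `Cc1ccc(C(=O)O)cc1OCCCCOc1ccc(C(=O)CC2CCCC2)c(O)c1C`. It differs from compound 2 in one place: methyl in place of methoxy on an aromatic carbon. For the measured compounds named here, nothing among the measured compounds shows what this change does in this assay. The expectation is a small step at most, not beyond the scatter in either direction, so the estimated step is a 1.2-fold higher number from compound 2 to compound 3 (0.07 log units; within the scatter). On that basis compound 3 is estimated at 1200 nM in this assay, with an expected range from 400 nM to 3600 nM.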

Compound 3, half-maximal effective concentration: > 10000 nM
Compound 3 was reported as a limit; the forecaster's own chance of this, stated with the estimate: 15%; at least 8.3-fold (0.92 log units) between middle value and limit.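

In this assay, among these compounds, methyl in place of methoxy, para to a carboxy group and ortho to a large group, gives an at least 9.8-fold higher number from compound 2 to compound 3 (0.99 log units; beyond the scatter), the first step and one beyond the scatter. This position is therefore not indifferent to the group it carries, and of the two groups tested here, only the methoxy of compound 2 gives a reading inside the range of the assay. Compound 3 gives > 10000 nM, which is a limit and not a number: the limit of > 10000 nM in this assay, at which 1 of the 3 values shown sits.

One pair cannot tell whether the step follows from the oxygen that leaves or from the methyl that enters. Going by these compounds, how a hydroxy group, an ethoxy group or a chlorine atom would read at this position remains open.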